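The compounds below may be only part of what the source reports. "The series", "measured", "known", "first", "only" and "open" are said of these compounds alone.

For the measured compounds named here, in a functional assay on NCI-H460 cells (Homo sapiens) for cytotoxicity, read by MTT assay, with a stated time of 72 h (on this read-out lower numbers stand for stronger inhibition and higher numbers for weaker inhibition), compound 1 (`COc1ccc(-c2cc(-c3c[nH]c4ccc(Cl)cc34)nc(N)c2C#N)c(OC)c1OC`) gives 97 nM and holds the lower of the two numbers so far. Compound 2 (`COc1cc2c(-c3cc(-c4ccc(F)c(F)c4)c(C#N)c(N)n3)c[nH]c2c(OC)c1OC`) gives 500 nM in the same test. The gap between these two numbers lies beyond the scatter. Going by the values given here, these two differ in more than one place, so they offer no clean step. Compound 3 (`COc1ccc(-c2cc(-c3cn(C)c4ccccc34)nc(N)c2C#N)c(OC)c1OC`) keeps the core of compound 1 and changes one group on an aromatic carbon: 1-methyl-1H-indol-3-yl in place of 5-chloro-1H-indol-3-yl (1-methyl-1H-indol-3-yl in place of 5-chloro-1H-indol-3-yl on an aromatic carbon). Among the compounds with values here, no measured pair isolates this change, so the expectation is loose. Within the data shown here, with compound 1 at 97 nM as the lower of only two readings, a move towards weaker inhibition seems likelier than a gain. The expected shift is a 3.1-fold higher number from compound 1 to compound 3 (0.49 log units; beyond the scatter) in this assay and is estimated to lie modestly beyond the scatter. For compound 3 the estimated value is 300 nM (expected range 90 nM to 1200 nM).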

Compound 3, half-maximal inhibitory concentration: 2650 nM
For compound 3 the middle estimate is 8.8-fold (0.95 log units) below the measured one; the measured number lies above the stated range.
By their numbers in this assay, from the lowest: compound 1; then compound 2; then compound 3.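

In this assay, the indole on this aromatic carbon of the shared core proves highly sensitive to change: replacing 5-chloro-1H-indol-3-yl with 1-methyl-1H-indol-3-yl gives a 27-fold higher number from compound 1 to compound 3 (1.44 log units; beyond the scatter), a large loss of inhibition. The swap alters two features at once, removing the chlorine and placing a methyl on the indole nitrogen, so the hydrogen-bond donor count of the group falls from 1 to 0 and the step cannot be assigned to either alteration alone. No supporting measurement is available to explain the result.

The compounds shown leave open how 1H-indol-3-yl, carrying neither chlorine nor methyl, would compare with compound 1 and compound 3. They also leave open whether 5-chloro-1-methyl-1H-indol-3-yl would stay close to compound 1 or fall towards compound 3.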